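The source may report more compounds than this note shows. Statements on the series, on what has been measured and on what is new or still open speak of the compounds shown alone.

Compound 1: `C[C@H]1Cn2ncc(N3CC(c4ccccc4)CC3=O)c2CN1C(=O)Nc1cc(F)c(F)c(F)c1`, in this measurement 12800 nM
Compound 2: `O=C1c2ccccc2CN1c1cnn2c1CN(C(=O)Nc1cc(F)c(F)c(F)c1)C(C1CC1)C2`, in this measurement 38500 nM
Compound 3: `O=C1CC(Oc2ncccn2)CN1c1cnn2c1CN(C(=O)Nc1cc(F)c(F)c(F)c1)C(C1CC1)C2`, where the result is only a limit of the assay, > 200000 nM

Of the compounds shown here, three sharing one core have been tested in a toxicity assay on HepG2 2.2.15 cells (Homo sapiens) for cytotoxicity, read by CellTiter-Glo; a higher number here means that more compound is tolerated, a lower number that less compound is tolerated. Compound 2 gives the higher of the two actual numbers, and its gap to compound 1 is beyond the usual scatter. For compound 3 the assay reached only a limit, so that value cannot be ranked against the others as a number; it merely shows that (the limit of > 200000 nM in this assay, at which 1 of the 3 values shown sits).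

The next compound, compound 4 `O=C(Nc1cc(F)c(F)c(F)c1)N1Cc2c(-c3ccc(F)cc3)cnn2CC1C1CC1`, has not yet been measured. It differs from compound 2 by a group of 7 heavy atoms (6 carbon, 1 fluorine; one six-membered aromatic ring of carbon only) in place of a group of 10 heavy atoms (8 carbon, 1 nitrogen, 1 oxygen; one five-membered non-aromatic ring with 1 hetero atom, one six-membered aromatic ring of carbon only), on an aromatic carbon.

For the measured compounds named here, no measured pair of compounds in this set differs in just one place, so there is no measured step to lean on. Of the three results in this assay, the two numbers lie fairly close together and the third sits at the limit, giving no sign that swapping one aromatic group for another shifts tolerance strongly. The expectation is therefore a step from compound 2 of a 1.1-fold lower number from compound 2 to compound 4 (0.04 log units; within the scatter), which is not beyond the scatter. Compound 4 is estimated at 35000 nM, within a range from 12000 nM to 150000 nM.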

Compound 4, half-maximal cytotoxic concentration: 38500 nM
For compound 4 the middle estimate is 1.1-fold (0.04 log units) below the measured one; low and high end bracket the measured number.
By their numbers in this assay, from the lowest: compound 1; then compounds 2 and 4 (each within the scatter of the next). At a limit, above all of these: compound 3.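

In this assay, for the compounds shown here, the first comparison in this set that changes only one place reads no change at the digits printed from compound 2 to compound 4 (within the scatter). The change sits on an aromatic carbon, and it shows that 4-fluorophenyl can take the place of the larger group carried by compound 2 with no readable shift in tolerated concentration, even though the five-membered non-aromatic ring and the hydrogen-bond acceptor of that group are lost. Nothing among the measurements explains why the number stays put here.

Going by these compounds, this is a single replacement at a single position, so it remains open whether an amine, a carboxylic acid or a plain phenyl ring on the same aromatic carbon would also leave the number in place, or whether a change of this kind would behave the same way with the methyl group of compound 1 on the shared core. Going by these compounds alone, it also remains open how far tolerance at this position can rise, since the only compound reaching a limit of the assay is compound 3, at > 200000 nM.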